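The source may hold more compounds than are shown below. What is called first, only, known or untested is meant among the compounds shown, and "the series" means these compounds.

Among the measured compounds shown here, compound 1 `COc1cncc(-c2ccc(C(N)=O)cc2)c1` stands as the lower of the two numbers so far obtained in an assay on cells for inhibition of MAP kinase-interacting serine/threonine-protein kinase 1 (Homo sapiens), read by mobility shift assay, with stated times of 10 min and 60 min, in the presence of a further agent that is not named here (a higher number here means a weaker inhibitor, a lower number a stronger inhibitor), where compound 1 gives 3000 nM. Compound 2 `NC(=O)c1ccc(-c2ccc(N)nc2)cc1` gives 34000 nM in this assay, a number far enough from that of compound 1 to fall beyond the usual scatter. Compound 3 `NC(=O)c1ccc(-c2cncc(Cl)c2)cc1` has not yet been measured; it differs from compound 1 by chloro in place of methoxy on an aromatic carbon, a chloro in place of methoxy on an aromatic carbon. For the measured compounds named here, no measured pair shows a comparable change, so no shift beyond the scatter is expected from it. Compound 3 is therefore estimated at 3000 nM in this assay, within a range of 1000 nM to 9000 nM. The expected step of no change at the digits printed from compound 1 to compound 3 (within the scatter) is thus essentially none beyond the scatter.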

Compound 3, half-maximal inhibitory concentration: 14200 nM
For compound 3 the middle estimate is 4.7-fold (0.68 log units) below the measured one; the measured number lies above the stated range.
By their numbers in this assay, from the lowest: compound 1; then compound 3; then compound 2.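

Chloro in place of methoxy on this aromatic carbon, two atoms from the ring nitrogen, is not a neutral exchange in this assay. The change gives a 4.7-fold higher number from compound 1 to compound 3 (0.68 log units; beyond the scatter) and so weakens inhibition modestly. Among the compounds shown here, this is the first measured change at this position, and here methoxy gives the lower number of the two groups compared. Going by these compounds, whether ethoxy, hydroxy or a nitrile on this same carbon would match methoxy remains open, as does whether a group on this carbon could give a number lower than that of compound 1. No measurement given here accounts for this step.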